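The compounds below may be only part of what the source reports. "The series", "measured", "known", "first", "only" and "open" are said of these compounds alone.

Of the compounds shown here, three built on the same core have been measured so far. Tested in a functional assay on HCT-116 cells (Homo sapiens) for cytotoxicity, read by MTT assay, with a stated time of 72 h (on this read-out lower numbers stand for stronger inhibition and higher numbers for weaker inhibition), compound 1 (`COc1ncc(-c2ccc3nc(NC(=O)NCC(=O)N4CCCCC4)nn3c2)cc1NS(=O)(=O)c1ccc(F)cc1`) gives 130 nM while compound 2 (`COc1ncc(-c2ccc3nc(NC(=O)NCCN4CCCC4)nn3c2)cc1NS(=O)(=O)c1ccc(F)cc1`) gives 230 nM and compound 3 (`COc1ncc(-c2ccc3nc(NC(=O)NCCN4CCCCC4)nn3c2)cc1NS(=O)(=O)c1ccc(F)cc1`) gives 150 nM as its value. Compound 3 therefore sits among its two neighbours, and its steps to both stay within the usual scatter of repeated measurements. Compound 4 (`COc1ncc(-c2ccc3nc(NC(=O)NCCN(C)C)nn3c2)cc1NS(=O)(=O)c1ccc(F)cc1`) differs from compound 3 at a single place (dimethylamino in place of piperidin-1-yl on a saturated chain carbon, two bonds along the chain from an amide-type nitrogen) with dimethylamino in place of piperidin-1-yl on a saturated chain carbon, two bonds along the chain from an amide-type nitrogen.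

The nearest guide is the exchange of pyrrolidin-1-yl for piperidin-1-yl at this same place (a 1.5-fold lower number from compound 2 to compound 3 (0.19 log units; within the scatter)). Two further steps changed the chain itself, one ending in piperidin-1-yl (a 1.2-fold higher number from compound 1 to compound 3 (0.06 log units; within the scatter)) and one ending in pyrrolidin-1-yl (a 1.8-fold higher number from compound 1 to compound 2 (0.25 log units; within the scatter)). All three stayed within the scatter. Among the measured compounds shown here, no measured compound yet carries a group without a ring here, so that part of the change is untested. No step beyond the scatter is therefore expected in this assay for this exchange. The estimated step is a modest one (a 1.3-fold higher number from compound 3 to compound 4 (0.12 log units; within the scatter)). Compound 4 is thus expected at 200 nM with a likely range from 90 nM to 450 nM as the estimate.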

Compound 4, half-maximal inhibitory concentration: 220 nM
Beside the measured number, compound 4's estimate is 1.1-fold (0.04 log units) below it; low and high end bracket the measured number.
By their numbers in this assay, from the lowest: compounds 1, 3, 4 and 2 (each within the scatter of the next).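

Removing the ring from this position changes little in this assay: dimethylamino on the saturated chain carbon, two bonds along the chain from an amide-type nitrogen, gives a number within the scatter of the piperidin-1-yl group (a 1.5-fold higher number from compound 3 to compound 4 (0.17 log units; within the scatter)) and of the pyrrolidin-1-yl group (a 1.0-fold lower number from compound 2 to compound 4 (0.02 log units; within the scatter)). Among the compounds shown here, the earlier compounds compared only rings here, so this is the first sign that a ring is not needed at this place for cytotoxicity on these cells, and that dimethylamino, with 3 heavy atoms against the 6 of piperidin-1-yl, serves as well. The comparison with the chain ending in (piperidin-1-yl)carbonyl points the same way (a 1.7-fold higher number from compound 1 to compound 4 (0.23 log units; within the scatter)), so all four compounds now lie within the scatter of one another.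

Still open, going by these compounds, is whether any change at this end of the chain moves the number beyond the scatter, for instance a morpholin-4-yl ring, a primary amine, a carboxylic acid or a longer chain between the two nitrogens. Nothing given here offers a measured explanation for why these groups read so much alike.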